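Cytotoxicity notes: from compound 1 to compound 4

The source may hold more compounds than are shown below. What is called first, only, known or untested is meant among the compounds shown, and "the series" means these compounds.

Compound 1 `OC[C@H]1O[C@@H](n2cnc3c(NCc4ccc(F)cc4)ncnc32)[C@H](O)[C@@H]1O` — in an ADME assay on NIH3T3 cells (Mus musculus) for cytotoxicity, with a stated time of 72 h (a higher number here means a weaker inhibitor, a lower number a stronger inhibitor), compound 1 gives 44300 nM.
Compound 2 `OC[C@H]1O[C@@H](n2cnc3c(NCc4ccccc4Br)ncnc32)[C@H](O)[C@@H]1O` — in this assay compound 2 reaches only a limit, > 166000 nM.
Compound 3 `OC[C@H]1O[C@@H](n2cnc3c(NCc4ccc(Cl)c(Cl)c4)ncnc32)[C@H](O)[C@@H]1O` — in this assay compound 3 has no result reported, "not determined" (no result reported).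
Compound 4 `COc1cccc(CNc2ncnc3c2ncn3[C@@H]2O[C@H](CO)[C@@H](O)[C@H]2O)c1O` — not yet measured in this assay.

For the measured compounds named here, compound 1 holds the only plain number in this assay; compound 2 sits at a limit and compound 3 has no result, so compound 1 cannot be ranked against either. Going by the values given here, the single measured step, an at least 3.7-fold higher number from compound 1 to compound 2 (0.57 log units; beyond the scatter), also swaps the group on a saturated chain carbon bound to a nitrogen on an aromatic ring, and its size rests on the limit (the limit of > 166000 nM in this assay, at which 1 of the 3 values shown sits).

The change now followed is 2-hydroxy-3-methoxyphenyl in place of 4-fluorophenyl on a saturated chain carbon bound to a nitrogen on an aromatic ring. Among the compounds with values here, it differs in kind from the change to compound 2, so the one measured step gives only loose guidance. Given that it pointed toward a weaker inhibitor, a modest move in the same direction is expected, with a fair chance that only a limit is reported. Compound 4 is estimated at 80000 nM, within 25000 nM to 200000 nM. The step expected is a 1.8-fold higher number from compound 1 to compound 4 (0.26 log units; within the scatter).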

Compound 4, half-maximal inhibitory concentration: > 166000 nM
Compound 4: only a limit was reported; the forecaster's own chance of this, stated with the estimate: 35%; at least 2.0-fold (0.31 log units) between middle value and limit.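

In this assay, replacing the 4-fluorophenyl on a saturated chain carbon bound to a nitrogen on an aromatic ring with 2-hydroxy-3-methoxyphenyl gives an at least 3.7-fold higher number from compound 1 to compound 4 (0.57 log units; beyond the scatter), so the shift toward a higher number is no longer tied to 2-bromophenyl alone. Both replacements with a readable step now end at a limit rather than a number, and the size of each step rests on it: the limit of > 166000 nM in this assay, at which 2 of the 4 values shown sit. The step from compound 2 to compound 4 cannot be read, since both values are limits, and their two groups remain unordered.

For the compounds shown here, with compound 3 lacking a result, the 4-fluorophenyl of compound 1 remains the only group here with a plain number. Going by these compounds, what an unsubstituted phenyl or a 4-methoxyphenyl would give at this position remains open, as does whether any group there gives a lower number than compound 1.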